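From 4-fluorophenyl to 3-nitrophenyl on a shared core

This account rests on a few compounds, and the source may have more. Where it says the series, first, only, none or still open, it means among the compounds named here.

For the measured compounds named here, in a toxicity assay (Homo sapiens) for cytotoxicity, read by MTT assay, with a stated time of 48 h (a lower number here means a stronger inhibitor, a higher number a weaker inhibitor), compound 2 (`O=C1C(O)=C(C(c2ccc(F)cc2)c2c[nH]c3ccccc23)C(=O)c2ccccc21`) gives 65200 nM as the higher of the two actual numbers so far. Compound 3 (`O=C1C(O)=C(C(c2cccs2)c2c[nH]c3ccccc23)C(=O)c2ccccc21`) gives 31300 nM as the other number. Compound 1 (`COc1ccccc1C(C1=C(O)C(=O)c2ccccc2C1=O)c1c[nH]c2ccccc12`) is recorded only as a limit of > 200000 nM and not as a number.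

Compound 4 (`O=C1C(O)=C(C(c2cccc([N+](=O)[O-])c2)c2c[nH]c3ccccc23)C(=O)c2ccccc21`) has not yet been measured. It differs from compound 2 in one group on the saturated chain carbon: 3-nitrophenyl in place of 4-fluorophenyl on a saturated chain carbon bound to an aromatic carbon and a double-bonded ring carbon is the whole of the change.

Earlier swaps at this same carbon offer some guidance. Moving away from compound 1 gave an at least 3.0-fold lower number from compound 1 to compound 2 (0.48 log units; beyond the scatter) and also an at least 6.3-fold lower number from compound 1 to compound 3 (0.80 log units; beyond the scatter) but both steps start from a limit, so they show only that the group here can matter. Going by the values given here, the one step joining two actual numbers is a 2.1-fold lower number from compound 2 to compound 3 (0.32 log units; beyond the scatter) and it is modest. Among the compounds with values here, no measured compound carries a 3-nitrophenyl group, so the direction stays open, and no step beyond the scatter is expected in this assay on this evidence. The estimate amounts to a 1.4-fold lower number from compound 2 to compound 4 (0.16 log units; within the scatter) as the expected step. Compound 4 is expected at 45000 nM (estimated range 15000 nM to 140000 nM).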

Compound 4, half-maximal inhibitory concentration: 91200 nM
Compound 4: the middle estimate sits 2.0-fold (0.31 log units) below what was measured; the range from low to high includes it.
By their numbers in this assay, from the lowest: compound 3; then compounds 2 and 4 (each within the scatter of the next). At a limit, above all of these: compound 1.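

In this assay, 3-nitrophenyl in place of 4-fluorophenyl gives a 1.4-fold higher number from compound 2 to compound 4 (0.15 log units; within the scatter), so compounds 2 and 4 cannot be told apart, even though the entering group carries hydrogen-bond acceptors that the leaving group lacks. Against the five-membered sulfur ring of thiophen-2-yl, the same 3-nitrophenyl group gives a 2.9-fold higher number from compound 3 to compound 4 (0.46 log units; beyond the scatter), so with compound 4 added, compound 3 stands modestly lower than both substituted phenyl compounds that have actual numbers, rather than against compound 2 alone. Compound 1 is recorded as a limit and not as a number, so an at least 2.1-fold lower number from compound 1 to compound 4 (0.34 log units; beyond the scatter) gives only a bound on that step, and compound 1 is the one compound held there: the limit of > 200000 nM in this assay, at which 1 of the 4 values shown sits.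

The compounds shown leave open whether the thiophen-2-yl result reflects the ring itself, since a plain phenyl, a furan-2-yl or a second thiophene isomer would be needed to separate those readings. They also leave open what a non-aromatic group on this carbon, such as a cyclohexyl ring, a short alkyl chain or a carboxylic acid, would do to the number in this assay.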